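The source may hold more compounds than are shown below. What is called first, only, known or untested is meant among the compounds shown, and "the series" means these compounds.

The study follows four close relatives built on one shared core. Compound 1 `Cc1cc(NC(=S)Cn2nnc(-c3ccccc3)n2)n(C2CCCCC2)n1`, compound 2 `Cc1cc(NC(=O)Cn2nnc(-c3ccccc3)n2)n(C2CCC(F)(F)CC2)n1` and compound 3 `Cc1cc(NC(=O)Cn2nnc(-c3cccc(Cl)c3)n2)n(C2CCCCC2)n1` have been measured in an assay on HEK293 cells for activation of Kir3.1/Kir3.2 (Homo sapiens), read by thallium flux; a lower number here means a smaller maximal response, a higher number a larger maximal response. In this assay compound 1 gives 80%, compound 2 gives 68%, and compound 3 gives 89%. Compound 3 therefore holds the highest of the three numbers, yet its reading lies within the usual scatter of that of compound 1, so those two cannot be ordered, while the reading of compound 2 lies beyond the scatter below it. For the measured compounds named here, no pair of measured compounds differs in only one place, so no measured step shows how a single group on the phenyl ring moves the maximal response.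

Compound 4 `Cc1cc(NC(=O)Cn2nnc(-c3cccc(F)c3)n2)n(C2CCCCC2)n1` differs from compound 3 in one place: fluoro in place of chloro on an aromatic carbon. Compound 1 offers only a loose comparison, since it differs from compound 3 in more than this group, and the value of compound 1, 80%, cannot isolate the effect of the fluoro group. The step from compound 3 to compound 4 is estimated at a number 7 percentage points lower from compound 3 to compound 4 (within the scatter), a slight decrease that is not expected to exceed the scatter. Compound 4 is accordingly expected to give 82% in this assay, within a range from 66% to 98%.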

Compound 4, largest response reached (Emax), in percent of the reference or control that the assay uses: 96%
Estimate against measurement, compound 4: 14 percentage points below, within the range that was stated.
By their numbers in this assay, from the lowest: compound 2; then compounds 1, 3 and 4 (each within the scatter of the next, the first and the last beyond it).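

For the compounds shown here, this is the first single-place step: the change from 3-chlorophenyl to 3-fluorophenyl gives a number 7 percentage points higher from compound 3 to compound 4 (within the scatter) in this assay, so the two halogens cannot be told apart at this aromatic carbon. Either group on this carbon therefore leaves the maximal response within the same band, something the earlier compounds could not show, as no two of them differed in one place only. No measured information bears on why this exchange leaves the reading within the scatter.

The compounds shown leave open whether a halogen is needed on this carbon at all, and what a bare hydrogen, a methoxy group, a nitrile or an amine in its place would do to the maximal response. Going by these compounds, the separate contributions of the thioamide in compound 1 and the difluorinated cyclohexyl ring in compound 2 also stay open, since neither compound is linked to compound 3 or compound 4 by a single-place step, and those steps cannot be read.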